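A Pyridine Ring in Place of Furan on Compound 3

The source may report more compounds than this note shows. Statements on the series, on what has been measured and on what is new or still open speak of the compounds shown alone.

Within the data shown here, in a functional assay on HCT-15 cells (Homo sapiens) for cytotoxicity, read by CCK-8 assay (a lower number here means a stronger inhibitor, a higher number a weaker inhibitor), compound 3 `Oc1ccc(-c2cc(-c3ccoc3)cc(-c3cccc(O)c3)n2)cc1` gives 930 nM, the only actual number among the three measured compounds. Compound 1 `Oc1cccc(-c2cc(-c3ccoc3)cc(-c3ccccc3O)n2)c1` reaches only the limit of > 50000 nM, which is a limit of the assay and not a number. Compound 2 `Oc1ccc(-c2cc(-c3ccoc3)cc(-c3ccccc3O)n2)cc1` likewise sits at the limit of > 50000 nM. The steps of an at least 53-fold lower number from compound 1 to compound 3 (1.73 log units; beyond the scatter) and an at least 53-fold lower number from compound 2 to compound 3 (1.73 log units; beyond the scatter) show that exchanging a 2-hydroxyphenyl group for a 4-hydroxyphenyl or 3-hydroxyphenyl group changes the read-out greatly, both values resting on (the limit of > 50000 nM in this assay, at which 2 of the 3 values shown sit).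

Compound 4 `Oc1ccc(-c2cc(-c3cccnc3)cc(-c3cccc(O)c3)n2)cc1` differs from compound 3 at a different position: pyridin-3-yl in place of furan-3-yl on an aromatic carbon. Among the measured compounds shown here, none of the measured steps touches the five-membered ring; all concern the hydroxyphenyl groups, so no measured step bears directly on this change. Compound 4 is therefore expected to give 1100 nM, with a range from 300 nM to 4000 nM, the expected step of a 1.2-fold higher number from compound 3 to compound 4 (0.07 log units; within the scatter) staying within the usual scatter.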

Compound 4, half-maximal inhibitory concentration: > 50000 nM
Compound 4 gave a limit, no number; the forecaster's own chance of this, stated with the estimate: 10%; middle value at least 45-fold (1.65 log units) away from the limit.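

Until this point, only the hydroxyphenyl groups had changed, so nothing was known about the position opposite the ring nitrogen. In this assay, pyridin-3-yl in place of furan-3-yl gives an at least 53-fold higher number from compound 3 to compound 4 (1.73 log units; beyond the scatter), which shows that this position is not indifferent to the ring it carries, even though the two rings share the same count of hydrogen-bond donors and acceptors. The result for compound 4 is a limit and not a number, so the full size of this step stays unknown: the limit of > 50000 nM in this assay, at which 3 of the 4 values shown sit.

With one pair, the effect of the ring nitrogen cannot be separated from that of the larger ring, a question that a phenyl or thiophen-3-yl group at this position could help answer. Also open, going by these compounds, is whether a quite different group here, such as an amine or a carboxylic acid, would give a measurable number.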